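The source may report more compounds than this note shows. Statements on the series, on what has been measured and on what is new or still open speak of the compounds shown alone.

Measured so far in a functional assay on DU-145 cells (Homo sapiens) for antiproliferative activity, read by MTT assay, with a stated time of 24 h; on this read-out higher numbers stand for weaker inhibition and lower numbers for stronger inhibition:
compound 2 `COc1cc(-c2cc(C(=O)/C=C/c3ccc(Cl)cc3)nc3cc(-c4ccccc4)nn23)cc(OC)c1OC`: 19500 nM
compound 3 `COc1ccc(-c2cc(C(=O)/C=C/c3ccc(Cl)cc3)nc3cc(-c4ccccc4)nn23)cc1OC`: 22400 nM
compound 1 `COc1ccc(C(=O)/C=C/c2cc(-c3cc(OC)c(OC)c(OC)c3)n3nc(-c4ccccc4)cc3n2)cc1OC`: 29900 nM

Compound 2 stands at the low end of the three numbers, but its distances to compound 3 and to compound 1 are both within the usual scatter, so the three compounds cannot be told apart on this assay. Among the measured compounds shown here, the single measured step, a 1.1-fold higher number from compound 2 to compound 3 (0.06 log units; within the scatter), changes a methoxy on the other aromatic ring and leaves the number essentially where it was.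

Compound 4 `COc1cc(-c2cc(C(=O)/C=C/c3ccccc3)nc3cc(-c4ccccc4)nn23)cc(OC)c1OC` is not yet measured. It differs from compound 2 in one place: hydrogen in place of chloro on an aromatic carbon. For the measured compounds named here, no measured pair removes a chloro, so the only step that bears on it is the one from compound 2 to compound 3, which shows that a small change on an outer aromatic ring of this series moved the number only within the scatter. A step of similar size, with no clear direction, is therefore expected here.

Compound 4 is expected to give about 25000 nM in this assay, with a likely range from 12000 nM to 50000 nM. The expected step of a 1.3-fold higher number from compound 2 to compound 4 (0.11 log units; within the scatter) is estimated to lie within the scatter.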

Compound 4, half-maximal inhibitory concentration: 16300 nM
For compound 4 the middle estimate is 1.5-fold (0.19 log units) above the measured one, within the range that was stated.
By their numbers in this assay, from the lowest: compounds 4, 2, 3 and 1 (each within the scatter of the next).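

In this assay, taking the chloro from the aromatic carbon para to a large group, which turns 4-chlorophenyl into phenyl, gives a 1.2-fold lower number from compound 2 to compound 4 (0.08 log units; within the scatter), so the chloro can go without a readable change in the number. Compound 2 and compound 3 both carry this chloro and could not show this, and compound 1 differs from them in more than one place. Nothing measured here bears on this result or offers a reason for it.

The compounds shown hold only chloro and hydrogen at this position, so they leave open whether a dimethylamino group, a carboxylic acid or a longer alkyl chain there would move the number beyond the scatter in this assay. They also leave open whether the exchange of chloro for hydrogen would read the same with the methoxy pattern of compound 3 on the other aromatic ring.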